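The source may report more compounds than this note shows. Statements on the series, on what has been measured and on what is new or still open speak of the compounds shown alone.

In an ADME assay on microsomes from liver (Homo sapiens) for metabolic stability, read by LC-MS, with a stated time of 30 min, tested at 1 uM (on this read-out higher numbers stand for fast clearance and lower numbers for slow clearance), the measured compounds read as follows.

Compound 1 `Nc1ccc2nnc(Cc3ccc4ncccc4c3)n2n1` gives < 7.6 mL.min-1.g-1 (a limit of the assay, not a number).
Compound 2 `COc1ccc(-c2ccc3nnc([C@@H](C)c4ccc5ncccc5c4)n3n2)cc1F` gives 281 mL.min-1.g-1 (a number).
Compound 3 `COc1ccc(-c2ccc3nnc([C@@H](C)c4ccc5ncccc5c4)n3n2)cc1C` gives 304 mL.min-1.g-1 (a number).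

Going by the values given here, compound 3 stands level with compound 2, the only measured step being a 1.1-fold higher number from compound 2 to compound 3 (0.03 log units; within the scatter) in this assay for methyl in place of fluoro. Compound 4 `C[C@@H](c1ccc2ncccc2c1)c1nnc2ccc(-c3ccccc3C#N)nn12` carries 2-cyanophenyl in place of 4-methoxy-3-methylphenyl on an aromatic carbon of the shared core. That measured step bears on this change only loosely, since it leaves the methoxy in place. With compound 3 at 304 mL.min-1.g-1 among the high numbers here, a moderate fall is expected rather than a rise, at low confidence. The estimated move is a 2.5-fold lower number from compound 3 to compound 4 (0.40 log units; beyond the scatter) in this assay as an expectation only. For compound 4 the expected value is 120 mL.min-1.g-1 with an estimated range from 40 mL.min-1.g-1 to 300 mL.min-1.g-1 in this read-out.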

Compound 4, intrinsic clearance in microsomes in the Homo sapiens assay: 23.1 mL.min-1.g-1
Beside the measured number, compound 4's estimate is 5.2-fold (0.72 log units) above it; measured number below the stated range.
By their numbers in the Homo sapiens assay, from the lowest: compound 4; then compounds 2 and 3 (each within the scatter of the next). At a limit, below all of these: compound 1.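

In the Homo sapiens assay, 2-cyanophenyl on this aromatic carbon gives a 13-fold lower number from compound 3 to compound 4 (1.12 log units; beyond the scatter) and a 12-fold lower number from compound 2 to compound 4 (1.09 log units; beyond the scatter), whereas methyl in place of fluoro stayed flat with a 1.1-fold higher number from compound 2 to compound 3 (0.03 log units; within the scatter). This position can therefore carry a large change in clearance when the whole aryl group is exchanged, which compounds 2 and 3 alone did not show. The same exchange also moves a physicochemical assay for solubility, measured as kinetic solubility, at pH 6.5; on this read-out higher numbers stand for higher solubility and lower numbers for lower solubility: the measured solubility of compound 3, 1770 nM, and of compound 4, 213000 nM, a 120-fold higher number (2.08 log units; beyond the scatter). In the physicochemical assay compound 3 gives 1770 nM and compound 4 gives 213000 nM.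

Compounds 3 and 4 differ in the whole aryl group, so the part played by the methoxy cannot be separated from that of the nitrile. As far as these compounds go, how a plain phenyl or a morpholine on this carbon would read remains open.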